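Benzimidazole replacement on the shared core: step to compound 4

A few compounds are considered here, and "the series" means these few. Any claim that something is new, unique, unknown or untested is made for them only; others in the source may bear on it.

Among the measured compounds shown here, in a functional assay on KB cells (Homo sapiens) for cytotoxicity, read by MTT assay, with a stated time of 48 h (a higher number here means a weaker inhibitor, a lower number a stronger inhibitor), compound 3 `CCn1cc(-c2nc3ccccc3s2)c(=O)c2cc(F)c(N3CCNCC3)nc21` gives 2400 nM and stands second highest of the three numbers so far; nearest to it is compound 1 `CCn1cc(-c2nc3ccccc3[nH]2)c(=O)c2cc(F)c(N3CCNCC3)nc21`, which gives 2000 nM, and furthest from it is compound 2 `CCn1cc(-c2nc3ccccc3o2)c(=O)c2cc(F)c(N3CCNCC3)nc21`, which gives 11700 nM. The measured steps are a 1.2-fold higher number from compound 1 to compound 3 (0.08 log units; within the scatter), a 5.9-fold higher number from compound 1 to compound 2 (0.77 log units; beyond the scatter) and a 4.9-fold lower number from compound 2 to compound 3 (0.69 log units; beyond the scatter).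

Compound 4 `CCn1cc(-c2nc3ccc(Cl)cc3[nH]2)c(=O)c2cc(F)c(N3CCNCC3)nc21` differs from compound 3 in one place: 6-chloro-1H-benzimidazol-2-yl in place of 1,3-benzothiazol-2-yl on an aromatic carbon.

The step that bears on this change is a 1.2-fold higher number from compound 1 to compound 3 (0.08 log units; within the scatter), which joins the benzothiazole to the benzimidazole and lies within the scatter. For the measured compounds named here, no measured pair shows the effect of a chloro substituent on the benzimidazole, so that part of the change rests on nothing. For compound 4 the expected step is therefore a 1.2-fold lower number from compound 3 to compound 4 (0.08 log units; within the scatter), that is, none beyond the scatter. In this assay compound 4 is estimated at 2000 nM, with a range from 700 nM to 6000 nM.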

Compound 4, half-maximal inhibitory concentration: 10300 nM
Estimate against measurement, compound 4: 5.2-fold (0.71 log units) below, and the stated range ends below it.
By their numbers in this assay, from the lowest: compounds 1 and 3 (each within the scatter of the next); then compounds 4 and 2 (each within the scatter of the next).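

In this assay, among the compounds shown here, chloro in place of hydrogen on the 1H-benzimidazol-2-yl group gives a 5.2-fold higher number from compound 1 to compound 4 (0.71 log units; beyond the scatter) and is the first substituent change at this place on the shared core, whereas the parent groups of compound 1 and compound 3 lie within the scatter of each other. The ring change and the chloro together give a 4.3-fold higher number from compound 3 to compound 4 (0.63 log units; beyond the scatter) and, with a 1.1-fold lower number from compound 2 to compound 4 (0.06 log units; within the scatter) within the scatter, the 6-chloro-1H-benzimidazol-2-yl group stands level with the 1,3-benzoxazol-2-yl group in this assay. Nothing at hand explains why chloro carries this step.

The compounds shown leave open whether the step belongs to chloro itself or would also follow from fluoro, methoxy or an amine on the same ring. As far as these compounds go, it also remains open whether chloro on the 1,3-benzothiazol-2-yl group would give a step of similar size.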